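Methyl scan on a biaryl benzanilide series

The source may report more compounds than this note shows. Statements on the series, on what has been measured and on what is new or still open speak of the compounds shown alone.

Measured compounds:
compound 1, `Cc1cccnc1-c1ccc(C(=O)Nc2ccc(C(F)(F)F)cc2)cc1`: 65 nM
compound 2, `Cc1nnc(-c2cccnc2-c2ccc(C(=O)Nc3ccc(C(C)(C)C)cc3)cc2)o1`: 387 nM
compound 3, `CC(C)(C)c1ccc(NC(=O)c2ccc(-c3ncccc3-c3nnco3)cc2)cc1`: 91 nM

All three were tested in a functional assay for antagonist activity at transient receptor potential cation channel subfamily V member 1 (Homo sapiens), read by FLIPR; on this read-out lower numbers stand for stronger inhibition and higher numbers for weaker inhibition. Compound 1 gives 65 nM and compound 3 gives 91 nM; these two numbers lie within the scatter of each other, so no order between them is claimed. The difference between the cores of compound 1 and compound 3 is not broken down here.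

One single-point change is already measured in the series: compound 3 to compound 2, (methyl in place of hydrogen on an aromatic carbon). The step is a 4.3-fold higher number from compound 3 to compound 2 (0.63 log units; beyond the scatter).

Compound 4, `Cc1cc(-c2ncccc2C)ccc1C(=O)Nc1ccc(C(F)(F)F)cc1`, is not yet measured. It arises from compound 1 by the same kind of change, (methyl in place of hydrogen on an aromatic carbon). The surroundings differ: in compound 2 the methyl enters on an aromatic carbon of a five-membered aromatic ring with 2 nitrogen and 1 oxygen, next to the ring nitrogen and next to the ring oxygen; in compound 4 it enters on an aromatic carbon of a six-membered aromatic ring of carbon only, ortho to a large group and meta to a 3-methylpyridin-2-yl group. Going by the values given here, the only precedent for adding a methyl is the measured step from compound 3 to compound 2, which raised the number. Placed beside it, the expected step for compound 4 in this assay is a 2.3-fold higher number from compound 1 to compound 4 (0.36 log units; beyond the scatter), a somewhat smaller rise than a 4.3-fold higher number from compound 3 to compound 2 (0.63 log units; beyond the scatter), because a 4.3-fold higher number from compound 3 to compound 2 (0.63 log units; beyond the scatter) belongs to a methyl on a different ring and its size cannot be assumed to carry over fully. Compound 4 is therefore estimated at 150 nM, with a range from 50 nM to 450 nM.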

Compound 4, half-maximal inhibitory concentration: > 4000 nM
Compound 4: a limit, no number (the forecaster's own chance of this, stated with the estimate: 5%); middle value at least 26-fold (1.42 log units) from the limit.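

In this assay compound 4 gives > 4000 nM, which is a limit of the assay and not a number. Going by these compounds alone, the step is an at least 61-fold higher number from compound 1 to compound 4 (1.78 log units; beyond the scatter), so placing a methyl on an aromatic carbon does not carry a single size of effect from one core to another: the same change on two cores in this assay, a 4.3-fold higher number (0.63 log units; beyond the scatter) from compound 3 to compound 2 and an at least 61-fold higher number (1.78 log units; beyond the scatter) from compound 1 to compound 4, at least 14-fold (1.16 log units) apart, beyond the scatter of two such steps This does not separate the contribution of the core from that of the ring receiving the methyl, since the two steps differ in both, and with only two such steps no general rule for this change can be drawn; the full size of the step to compound 4 also stays unknown.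

The compounds shown leave open whether the result for compound 4 is specific to a methyl or would also follow from another small group on the same aromatic carbon, such as a fluorine, a chlorine or a methoxy group. They also leave open what the same methyl, on the same ring, would do on the core of compound 3, which would show whether the size of the step follows the ring or the core.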